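The source may hold more compounds than are shown below. What is called first, only, known or untested is meant among the compounds shown, and "the series" means these compounds.

Measured so far:
Compound 1 `COC(=O)C1=C(C)NC(=O)NC1c1ccoc1`: 2%
Compound 2 `CC1=C(C(=O)OCc2ccccc2)C(c2ccoc2)NC(=O)N1`: 1%

In an assay on membranes from HeLa cells for displacement of a labelled ligand from adenosine receptor A3 (Homo sapiens), read by scintillation counting, with a stated time of 180 min, tested at 1 uM (on this read-out higher numbers stand for more inhibition at the one concentration tested (going by the name of the read-out) and lower numbers for less inhibition), compound 2 gives 1%, and compound 1 gives 2%; the step of a number 1 percentage points lower from compound 1 to compound 2 (within the scatter) separates them, so the two numbers are not distinguishable, and both show very little displacement.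

Compound 3 `CC1=C(C(=O)OCc2ccccc2)C(c2ccsc2)NC(=O)N1` differs from compound 2 by thiophen-3-yl in place of furan-3-yl on a saturated ring carbon. Going by the values given here, the one measured step, a number 1 percentage points lower from compound 1 to compound 2 (within the scatter), concerns the ester end of the core and not the five-membered ring, so it bears on the present change only indirectly: it shows that the core, with either ester, gives almost no displacement in this assay. Among the compounds with values here, no measured step exchanges one five-membered aromatic ring for another, so nothing in the data points to a step in either direction beyond the scatter.

Compound 3 is therefore expected to stay near the floor, with a step of a number 2 percentage points higher from compound 2 to compound 3 (within the scatter) that is not meaningful. The estimate for compound 3 in this assay is 3%, in the range -7% to 15%.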

Compound 3, a percentage reported as inhibition, at one concentration (the size of the read-out at that concentration, not a potency): 25%
Compound 3: the middle estimate sits 22 percentage points below what was measured; measured number outside the range, above it.
By their numbers in this assay, from the lowest: compounds 2 and 1 (each within the scatter of the next); then compound 3.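

In this assay, going by these compounds alone, the group on the saturated ring carbon is the first place where a single change moves the read-out beyond the scatter: thiophen-3-yl in place of furan-3-yl gives a number 24 percentage points higher from compound 2 to compound 3 (beyond the scatter) with the rest of the molecule unchanged. Ring size, heavy-atom count, and donor and acceptor counts stay the same across this change, so the step goes with sulfur in place of oxygen in the ring, whereas the ester change from compound 1 to compound 2 stayed within the scatter. Nothing available accounts for this step.

As far as these compounds go, whether the thiophen-3-yl gain carries over to the methyl ester of compound 1 remains open. So does how this position responds to a six-membered ring such as pyridin-3-yl, and the single-concentration read-out gives no potency for compound 3.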